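A few compounds are considered here, and "the series" means these few. Any claim that something is new, unique, unknown or untested is made for them only; others in the source may bear on it.

Measured compounds:
compound 1 `CCOC(=O)C1=C(C)N/C(=C/c2cc(C)n(-c3ccc(OC)cc3)c2C)C1=O`: 140000 nM
compound 2 `CCOC(=O)C1=C(C)N/C(=C/c2cc(C)n(Cc3ccccc3)c2C)C1=O`: 50000 nM

In an ADME assay on L6 cells (Rattus norvegicus) for cytotoxicity, read by resazurin assay, with a stated time of 72 h (on this read-out lower numbers stand for an effect already at smaller amounts and higher numbers for an effect only at larger amounts of compound), compound 1 gives 140000 nM, the highest of the two numbers shown, and compound 2 gives 50000 nM. Within the data shown here, the single measured step, benzyl in place of 4-methoxyphenyl on an aromatic nitrogen, gave a 2.8-fold lower number from compound 1 to compound 2 (0.45 log units; beyond the scatter). Compound 3 `CCOC(=O)C1=C(C)N/C(=C/c2cc(C)n(-c3ccc(CN4CCCCC4)cc3)c2C)C1=O` differs from compound 1 by (piperidin-1-yl)methyl in place of methoxy on an aromatic carbon. Among the measured compounds shown here, no measured step touches this methoxy position; the step from compound 1 to compound 2 changes a different group and bears on it only as a sign that the read-out can move beyond the scatter with one change on the shared core. Compound 3 is therefore expected to give a modestly lower number, with wide uncertainty, in this assay. The expected step is a 2.3-fold lower number from compound 1 to compound 3 (0.37 log units; beyond the scatter). For compound 3 the estimate is 60000 nM, ranging from 20000 nM to 160000 nM.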

Compound 3, half-maximal effective concentration: 81000 nM
Estimate against measurement, compound 3: 1.4-fold (0.13 log units) below, and the stated range covers the measured number.
By their numbers in this assay, from the lowest: compounds 2, 3 and 1 (each within the scatter of the next, the first and the last beyond it).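

In this assay, (piperidin-1-yl)methyl in place of methoxy on the aromatic carbon gave a 1.7-fold lower number from compound 1 to compound 3 (0.24 log units; within the scatter), so at this site, para to a large group, the larger group with its six-membered non-aromatic ring leaves the read-out within the usual scatter. Among these compounds, the earlier step changed only the group on the aromatic nitrogen, so this is the first reading of the methoxy position, and it shows no clear effect of this exchange. Nothing available explains this result or ties it to any feature of either group.

As far as these compounds go, it remains open whether a carboxylic acid, a primary amine or a longer chain ending in morpholine on this aromatic carbon would also stay within the scatter of compound 1. From the compounds shown here alone, it is equally open whether the same exchange would read alike with benzyl on the aromatic nitrogen, as in compound 2.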